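Losing the chloro from compound 2

The source may report more compounds than this note shows. Statements on the series, on what has been measured and on what is new or still open speak of the compounds shown alone.

Measured so far in a functional assay on SK-N-AS cells (Homo sapiens) for antiproliferative activity, with a stated time of 72 h; a higher number here means a weaker inhibitor, a lower number a stronger inhibitor
compound 1 `O=C(CCN(Cc1ccc(C(=O)NO)cc1)C(=O)c1ccccc1)NCc1ccccc1` gives 3310 nM
compound 2 `CN(C)c1ccc(C(=O)N(CCC(=O)NCc2ccc(Cl)cc2)Cc2ccc(C(=O)NO)cc2)cc1` gives 390 nM

Compound 2 at 390 nM holds the lower of the two numbers, and compound 1 sits above it by a gap beyond the scatter. One change leads from compound 2 to compound 3 `CN(C)c1ccc(C(=O)N(CCC(=O)NCc2ccccc2)Cc2ccc(C(=O)NO)cc2)cc1` (hydrogen in place of chloro on an aromatic carbon). In words, hydrogen takes the place of chloro on an aromatic carbon, so 4-chlorobenzyl becomes benzyl. Within the data shown here, no measured pair isolates this change, so the data give no direct measure of its size in this assay. A modest rise in the number is expected, perhaps none beyond the scatter, and the number for compound 3 is expected to stay lower than that of compound 1 at 3310 nM. The expected size is given by a 1.5-fold higher number from compound 2 to compound 3 (0.19 log units; within the scatter) as a small weakening. For compound 3 the estimate is 600 nM (expected range 250 nM to 1500 nM).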

Compound 3, half-maximal inhibitory concentration: 1420 nM
Beside the measured number, compound 3's estimate is 2.4-fold (0.37 log units) below it; the measured number falls inside the stated range.
By their numbers in this assay, from the lowest: compound 2; then compound 3; then compound 1.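

In this assay, the chloro of the 4-chlorobenzyl group carries weight at this position: a 3.6-fold higher number from compound 2 to compound 3 (0.56 log units; beyond the scatter), for hydrogen in place of chloro on an aromatic carbon, and this step lies beyond the scatter. Compound 3 also links the two earlier compounds through single changes, with dimethylamino in place of hydrogen on an aromatic carbon giving a 2.3-fold lower number from compound 1 to compound 3 (0.37 log units; beyond the scatter), likewise beyond the scatter, so each of the two changes counts on its own in this series. Nothing available explains either step.

Still open, as far as these compounds go, is how fluoro, methoxy or a carboxylic acid would read in place of chloro on that ring. Also open, from the compounds shown here alone, is whether the chloro step keeps its size when hydrogen replaces the dimethylamino group, or when a morpholine takes its place.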